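Carbonyl-side substituents on the shared core

The source may hold more compounds than are shown below. What is called first, only, known or untested is meant among the compounds shown, and "the series" means these compounds.

Measured so far in an assay on HEK293 cells for positive allosteric modulation of metabotropic glutamate receptor 5 (Homo sapiens), read by FLIPR; on this read-out higher numbers stand for an effect only at larger amounts of compound and lower numbers for an effect already at smaller amounts:
compound 1 `O=C(C1CCCO1)N1CC(c2nc(-c3cccc(Cl)c3)no2)C1` gives > 10000 nM, a limit of the assay and not a number.
compound 2 `O=C(c1ccc(F)cc1)N1CC(c2nc(-c3cccc(Cl)c3)no2)C1` gives > 10000 nM, likewise only a limit.
compound 3 `O=C([C@H]1CC2CCC1C2)N1CC(c2nc(-c3cccc(Cl)c3)no2)C1` gives 74 nM.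

For the measured compounds named here, compound 3 thus holds the only real number in this set; the two other values sit at the limit (the limit of > 10000 nM in this assay, at which 2 of the 3 values shown sit). Both steps toward compound 3 are large: the step of an at least 130-fold lower number from compound 1 to compound 3 (2.13 log units; beyond the scatter) and the step of an at least 130-fold lower number from compound 2 to compound 3 (2.13 log units; beyond the scatter) each show that the bicyclic carbon group on the carbonyl is the only substituent so far that brings the readout off the limit.

Compound 4 `CC1CN(C(=O)N2CC(c3nc(-c4cccc(Cl)c4)no3)C2)CC(C)O1` changes this very position: a group of 8 heavy atoms (6 carbon, 1 nitrogen, 1 oxygen; one six-membered non-aromatic ring with 2 hetero atoms) in place of a group of 7 heavy atoms (7 carbon; 2 five-membered non-aromatic rings of carbon only), on a carbonyl carbon. Going by the values given here, no measured pair covers a 2,6-dimethylmorpholin-4-yl group, so the two steps above are the only guide, and both point the same way: leaving the bicyclic carbon group has so far meant a return to the limit. The expectation for compound 4 in this assay is therefore a large step upward, a 68-fold higher number from compound 3 to compound 4 (1.83 log units; beyond the scatter), with a real chance that only a limit is reported. Compound 4 is estimated at 5000 nM, in the range 500 nM to 20000 nM.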

Compound 4, half-maximal effective concentration: > 10000 nM
Compound 4 was reported as a limit (the forecaster's own chance of this, stated with the estimate: 50%); at least 2.0-fold (0.30 log units) between middle value and limit.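

In this assay compound 4 is reported only as a limit, and this position now stands as follows: the limit of > 10000 nM in this assay, at which 3 of the 4 values shown sit. With 2,6-dimethylmorpholin-4-yl on the carbonyl carbon, the result is an at least 130-fold higher number from compound 3 to compound 4 (2.13 log units; beyond the scatter), so this position also loses the read-out when the entering ring is attached through its nitrogen and carries two methyl groups. Among the four compounds, only the carbon-only bicyclic group of compound 3 gives a number, while the oxygen-containing rings of compound 1 and compound 4 stay at the limit, as does the carbon-only aromatic ring of compound 2, so the absence of ring hetero atoms alone does not account for the pattern; the steps among compound 1, compound 2 and compound 4 cannot be read, so these three cannot be ranked.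

The compounds shown leave open whether a simple cyclopentyl or cyclohexyl ring, or an open chain such as tert-butyl, would keep a number at this position. They also leave open whether a carbon-only amine ring such as piperidin-1-yl would behave like compound 3 or compound 4.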